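The source may report more compounds than this note shows. Statements on the series, on what has been measured and on what is new or still open speak of the compounds shown alone.

Working notes on the series. Of the compounds shown here, two carry numbers so far. Compound 1 `N=C(N)c1ccc(-c2ccc(-c3cc(Cl)cc(Cl)c3)s2)s1` was run in a functional assay on MDA-MB-435 cells (Homo sapiens) for inhibition, read by sulforhodamine B assay, with a stated time of 48 h (a higher number here means a weaker inhibitor of growth, a lower number a stronger inhibitor of growth), and gives 1670 nM. Compound 2 `COc1ccc(-c2ccc(-c3ccc(C(=N)N)o3)o2)cc1`, built on a different shared core, gives 290 nM in this assay. Compound 2 therefore stands with the lower of the two numbers; the gap up to compound 1 lies beyond the scatter, so compound 2 is the stronger growth inhibitor of the pair. Among the measured compounds shown here, no measured pair differs in only one place, so the two values are not read as any single structural step.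

Compound 3 `N=C(N)c1ccc(-c2ccc(-c3ccc(Cl)cc3)o2)o1` is the next compound and has no number yet. It keeps the core of compound 2 and differs from it by chloro in place of methoxy on an aromatic carbon. For the measured compounds named here, no measured pair shows this exchange, so its effect is not anchored by data. The expectation is a small step, if any, toward a slightly higher number, and it may well stay within the scatter: a 1.6-fold higher number from compound 2 to compound 3 (0.19 log units; within the scatter). On that basis compound 3 is estimated at 450 nM in this assay, with a range from 150 nM to 1400 nM.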

Compound 3, concentration for 50% growth inhibition: 1380 nM
The estimate for compound 3 lay 3.1-fold (0.49 log units) below the measured number; low and high end bracket the measured number.
By their numbers in this assay, from the lowest: compound 2; then compounds 3 and 1 (each within the scatter of the next).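

In this assay, among the compounds shown here, the exchange of methoxy for chloro on an aromatic carbon, para to a large group, gives a 4.8-fold higher number from compound 2 to compound 3 (0.68 log units; beyond the scatter) and provides the only measured pair that differs in one place. The earlier compounds shown here could not show that the group at this position matters on the core of compound 2; this pair shows that it does, with methoxy carrying the lower number and so the stronger growth inhibition. No measurement at hand accounts for the size or direction of this step.

A single pair cannot separate what is lost with methoxy from what is gained with chloro, and it gives no trend across groups at this position. From the compounds shown here alone, whether hydroxy, amino, methyl or ethoxy at the same place would stay near compound 2, move toward compound 3 or fall outside both remains open, as does whether the same exchange would give a similar step on a different core.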